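Amide Variations on a Shared Core and Agonist Activity

The compounds below may be only part of what the source reports. "The series", "measured", "known", "first", "only" and "open" are said of these compounds alone.

Compound 1 `CCOC(=O)N1CCC(N2CCC[C@@H](NC(=O)C3CCCCC3)C2)CC1` in a functional assay on CHO cells for agonist activity at muscarinic acetylcholine receptor M5 (Rattus norvegicus) (a higher number here means that more compound is needed for the effect, a lower number that less compound is needed), gives > 10000 nM, which is a limit of the assay and not a number.
Compound 2 `CCOC(=O)N1CCC(N2CCC[C@@H](NC(=O)c3ccccc3Cl)C2)CC1` in this assay gives > 10000 nM, again a limit and not a number.
Compound 3 `CCOC(=O)N1CCC(N2CCC[C@@H](NC(=O)C3CCCC3)C2)CC1` in this assay gives > 10000 nM, also a limit.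

All three values sit at the same limit, as the limit of > 10000 nM in this assay, at which 3 of the 3 values shown sit, shows, so compound 2 stands exactly where compound 1 and compound 3 stand, and no ordering among them can be read. The steps a step that the two limits leave unreadable from compound 1 to compound 2, a step that the two limits leave unreadable from compound 1 to compound 3 and a step that the two limits leave unreadable from compound 2 to compound 3 are all of unreadable size for this reason.

Compound 4 `CCOC(=O)N1CCC(N2CCC[C@@H](NC(=O)c3ccc(F)cc3C)C2)CC1` is not yet measured. It differs from compound 2 in one place: 4-fluoro-2-methylphenyl in place of 2-chlorophenyl on a carbonyl carbon. The measured steps that bear on this change all involve swapping the group on that carbonyl carbon, and none of them gave a readable number, so there is no basis for expecting compound 4 to move beyond the limit in this assay. The step from compound 2 to compound 4 is therefore expected to be a number no higher from compound 2 to compound 4 (the limit leaves the size open). Compound 4 is estimated at 10000 nM, within a range from 3000 nM to 30000 nM.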

Compound 4, half-maximal effective concentration: > 10000 nM
Compound 4: a limit, no number; the forecaster's own chance of this, stated with the estimate: 80%; the middle value lies on the limit itself.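

Among the compounds shown here, compound 4 also gives a limit and not a number, so no step from compound 1, compound 2 or compound 3 to compound 4 can be read: the limit of > 10000 nM in this assay, at which 4 of the 4 values shown sit.

The compounds shown leave open which group on the carbonyl carbon, if any, would give a readable number in this assay on this shared core.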